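Compound 4 in the aryl urea series

The source may hold more compounds than are shown below. What is called first, only, known or untested is meant among the compounds shown, and "the series" means these compounds.

In an ADME assay on the whole organism with Oryza sativa as the target, tested at 1 uM (on this read-out lower numbers stand for a stronger effect and higher numbers for a weaker effect at the one concentration tested), compound 1 `C[C@@H](NC(=O)Nc1cccc(C(F)(F)F)c1)c1ccccc1` gives 72%, the lowest of the three numbers. Compound 2 `C[C@@H](NC(=O)Nc1cccc(F)c1)c1ccccc1` gives 95% and compound 3 `C[C@@H](NC(=O)Nc1cccc(Br)c1)c1ccccc1` gives 100%. Both lie beyond the scatter from compound 1: a number 23 percentage points higher from compound 1 to compound 2 (beyond the scatter), and a number 28 percentage points higher from compound 1 to compound 3 (beyond the scatter). Between compound 2 and compound 3 the step stays within the scatter: a number 5 percentage points higher from compound 2 to compound 3 (within the scatter).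

Compound 4 `C[C@@H](NC(=O)Nc1cccc(C(F)(F)F)c1F)c1ccccc1` differs from compound 1 by fluoro in place of hydrogen on an aromatic carbon. For the measured compounds named here, the trifluoromethyl group is kept in compound 4; every measured step exchanges that group for a halogen, and none adds a second substituent to the ring, so the measured steps bear on compound 4 only in that compound 1, the compound carrying trifluoromethyl, is the one with the lowest number, at 72%. With the trifluoromethyl retained, compound 4 is expected to stay near compound 1, with no step beyond the scatter in this assay: a number 2 percentage points lower from compound 1 to compound 4 (within the scatter). The estimate for compound 4 is 70%, within 50% to 90%.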

Compound 4, a percentage reported as activity, at one concentration (the size of the read-out at that concentration, not a potency): 99%
Beside the measured number, compound 4's estimate is 29 percentage points below it; measured number outside the range, above it.
By their numbers in this assay, from the lowest: compound 1; then compounds 2, 4 and 3 (each within the scatter of the next).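

In this assay, fluoro in place of hydrogen on an aromatic carbon, ortho to a trifluoromethyl group, gives a number 27 percentage points higher from compound 1 to compound 4 (beyond the scatter). For the compounds shown here, this position therefore responds to a single added fluoro, and retaining trifluoromethyl does not by itself preserve the low number of compound 1, whereas the earlier steps showed only what happens when that group is exchanged for a halogen. Nothing available explains the shift.

Still open, from the compounds shown here alone, is whether this step belongs to fluoro specifically or would also appear with a methyl, a methoxy or an amine on the same aromatic carbon. Also open, going by these compounds, is whether the step depends on the neighbouring trifluoromethyl group or would persist with a different substituent on the ring of the shared core.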